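The compounds below may be only part of what the source reports. "The series", "measured", "known", "first", "only" and "open" are said of these compounds alone.

Measured so far in an assay on cells for activation of probable G-protein coupled receptor 34 (Mus musculus), with a stated time of 1 h; on this read-out lower numbers stand for smaller maximal responses and higher numbers for larger maximal responses:
- compound 1, `N[C@@H](COP(=O)(O)OCCCOC(=O)CCc1ccccc1OCc1cccc(OC2CCCCC2)c1)C(=O)O`: compound 1 gives 0.11
- compound 2, `N[C@@H](COP(=O)(O)OCCCOC(=O)CCc1ccccc1OCc1cccc(Oc2ccccc2Cl)c1)C(=O)O`: compound 2 gives 0.069

Going by the values given here, compound 2 stands with compound 1 as the only neighbour on this read-out, and the two sit within the scatter of each other: the change of a number 0.041 lower from compound 1 to compound 2 (within the scatter) is too small to read as a difference. Both maximal responses are small fractions of the reference agonist's.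

Compound 3, `N[C@@H](COP(=O)(O)OCCCOC(=O)CCc1ccccc1OCc1cccc(Oc2ccc(Cl)cc2)c1)C(=O)O`, is not yet measured. It differs from compound 2 by 4-chlorophenyl in place of 2-chlorophenyl on an oxygen on an aromatic ring.

Among the compounds with values here, the one measured step, from compound 1 to compound 2, swaps a cyclohexyl for a 2-chlorophenyl on the same oxygen and lands within the scatter; it does not touch the position of the chlorine on the phenyl, so no measured step bears directly on the move from 2-chlorophenyl to 4-chlorophenyl. With the two aryl-ether and cycloalkyl-ether analogues both giving low maximal responses, no step beyond the scatter is expected in this assay for compound 3, and the expected change is a number 0.011 higher from compound 2 to compound 3 (within the scatter). Compound 3 is thus estimated at 0.08, with a range from 0.03 to 0.17.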

Compound 3, intrinsic activity: the largest response reached, as a fraction of the reference agonist's: 0.76
Estimate against measurement, compound 3: 0.68 below; the measured number lies above the stated range.
By their numbers in this assay, from the lowest: compounds 2 and 1 (each within the scatter of the next); then compound 3.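

In this assay, the change a number 0.69 higher from compound 2 to compound 3 (beyond the scatter) involves two groups with the same atoms and the same counts, so at this position on the oxygen on an aromatic ring, the place of the chlorine on the phenyl separates a small maximal response from a large one. The step a number 0.65 higher from compound 1 to compound 3 (beyond the scatter) contrasts with a number 0.041 lower from compound 1 to compound 2 (within the scatter), so a chlorophenyl in place of cyclohexyl is not enough in itself: only the 4-chlorophenyl stands clear of cyclohexyl, while the 2-chlorophenyl does not. No accompanying data bear on what lies behind this large step.

Still open, as far as these compounds go, is whether the chlorine itself matters or only that something occupies its place in the 4-chlorophenyl, which a phenyl without chlorine, or a fluorine or a methyl in place of that chlorine, would help to settle. Also open, from the compounds shown here alone, is whether the 4-chlorophenyl keeps this maximal response when the ester in the shared core gives way to an amide.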